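This account rests on a few compounds, and the source may have more. Where it says the series, first, only, none or still open, it means among the compounds named here.

Compound 1 `Cc1c2cc[n+](C)cc2c(C)c2c3c([nH]c12)C=CC(=O)[C@@]31O[C@@H]2[C@H](O1)[C@@H](CO)O[C@H]2n1cnc2c(N)ncnc21` gives 0.8 uM in a functional assay on L1210 cells (Mus musculus) for cytotoxicity; on this read-out lower numbers stand for stronger inhibition and higher numbers for weaker inhibition. Compound 2 `Cc1c2cc[n+](C)cc2c(C)c2c3c([nH]c12)C=CC(=O)[C@@]31O[C@@H]2[C@H](O1)[C@@H](CO)O[C@H]2n1cnc2c(O)nc(N)nc21` gives 0.8 uM. Compound 3 `Cc1c2cc[n+](C)cc2c(C)c2c3c([nH]c12)C=CC(=O)[C@@]31O[C@@H]2[C@H](O1)[C@@H](COP(=O)(O)O)O[C@H]2n1cnc2c(O)nc(N)nc21` gives > 1 uM, which is a limit of the assay and not a number.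

Compound 3 therefore stands only at a limit; of the values shown, (the limit of > 1 uM in this assay, at which 1 of the 3 values shown sits). Compound 4 `Cc1c2cc[n+](C)cc2c(C)c2c3c([nH]c12)C=CC(=O)[C@@]31O[C@@H]2[C@H](O1)[C@@H](COP(=O)(O)O)O[C@H]2n1ccc(N)nc1=O` differs from compound 3 by a group of 8 heavy atoms (4 carbon, 3 nitrogen, 1 oxygen; one six-membered aromatic ring with 2 hetero atoms) in place of a group of 11 heavy atoms (5 carbon, 5 nitrogen, 1 oxygen; one five-membered aromatic ring with 2 hetero atoms, one six-membered aromatic ring with 2 hetero atoms), on a saturated ring carbon. Going by the values given here, two measured steps bear on this. An earlier exchange of the ring group on a saturated ring carbon gave no change at the digits printed from compound 1 to compound 2 (within the scatter). The step that added the phosphorus-bearing group gave an at least 1.2-fold higher number from compound 2 to compound 3 (0.09 log units; that floor lies within the scatter). The new ring exchange is thus expected to move the number little, and compound 4 is expected to sit near the limit of compound 3, with a step that the limit leaves unreadable from compound 3 to compound 4. Compound 4 is estimated at 2 uM, between 0.8 uM and 6 uM.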

Compound 4, concentration for 50% inhibition: 12.8 uM
Compound 4: the middle estimate sits 6.4-fold (0.81 log units) below what was measured, and the stated range ends below it.
By their numbers in this assay, from the lowest: compounds 1 and 2 (each within the scatter of the next); then compound 4.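

The step from compound 3 to compound 4 cannot be read, because compound 3 stands only at a limit of the assay: the limit of > 1 uM in this assay, at which 1 of the 4 values shown sits.

The compounds shown leave open how much this ring-group exchange itself changes the number in this assay.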